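Plasma free fraction across the sulfonyl variants of the series

A few compounds are considered here, and "the series" means these few. Any claim that something is new, unique, unknown or untested is made for them only; others in the source may bear on it.

The shared core carries an acid-bearing aryl ether joined through an alkyne to a second aromatic ring that bears a sulfonyl group; the three analogues differ only in what sits on that sulfonyl sulfur and on the adjacent aromatic position. Going by the values given here, compound 1 `CCCS(=O)(=O)c1ccc(F)c(C#Cc2cc(Cl)ccc2OCC(=O)O)c1` is the only member with a number: in an ADME assay on a cell-free system (plasma, Mus musculus) (on this read-out higher numbers stand for a larger free fraction and lower numbers for a smaller free fraction), compound 1 gives 0.007, a very small free fraction. Compound 2 `COCCNS(=O)(=O)c1ccc(C)c(C#Cc2cc(Cl)ccc2OCC(=O)O)c1` was run in this assay but compound 2 returned "not determined" (no result reported), so compound 2 stands nowhere on the scale; it anchors the comparison by structure alone. Compound 3 `Cc1ccc(S(=O)(=O)N(C)C)cc1C#Cc1cc(Cl)ccc1OCC(=O)O` differs from compound 2 in one place: dimethylamino in place of (2-methoxyethyl)amino on a sulfonyl sulfur. Among the compounds with values here, with no measured step anywhere in the set, the change from compound 2 to compound 3 is not expected to move the free fraction beyond the usual scatter in either direction. For compound 3 the free fraction in this assay is estimated at 0.01, within 0.004 to 0.03, anchored on compound 1 at 0.007 as the only measured point.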

Compound 3, unbound fraction: 0.01
Compound 3: middle estimate and measured number agree at the digits printed; low and high end bracket the measured number.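

No step can be read between compound 2 and compound 3: compound 2 has no single number in this assay, while compound 3 gives 0.01. No available evidence bears on this result. The compounds shown leave open what replacing (2-methoxyethyl)amino with dimethylamino on a sulfonyl sulfur does to the free fraction.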